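From 4-cyanophenyl to thiophen-2-yl on the shared core

The compounds below may be only part of what the source reports. "The series", "measured", "known", "first", "only" and "open" are said of these compounds alone.

Among the compounds with values here, in a functional assay on U-87MG ATCC cells for inhibition, with U-87 MG (Homo sapiens) as the target, read by MTT assay, with a stated time of 48 h (on this read-out higher numbers stand for weaker inhibition and lower numbers for stronger inhibition), compound 1 `C(=C/c1nc2ccccn2c1Sc1ccccc1)\c1ccccc1` gives 59200 nM and compound 2 `N#Cc1ccc(-c2nc3ccccn3c2Sc2ccccc2)cc1` gives 65500 nM, so compound 2 stands level with its only measured neighbour. Compound 3 `c1ccc(Sc2c(-c3cccs3)nc3ccccn23)cc1` differs from compound 2 at one place, with thiophen-2-yl in place of 4-cyanophenyl on an aromatic carbon. Within the data shown here, the only measured step at that carbon, a 1.1-fold higher number from compound 1 to compound 2 (0.04 log units; within the scatter), put 4-cyanophenyl in place of 2-phenylethenyl and stayed within the scatter. A single step is thin evidence, and neither measured compound carries a five-membered aromatic ring there. Even so, no change beyond the scatter is expected in this assay, in either direction. The expected step is a 1.1-fold lower number from compound 2 to compound 3 (0.04 log units; within the scatter). Compound 3 is estimated at 60000 nM, with an expected range of 25000 nM to 140000 nM.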

Compound 3, half-maximal inhibitory concentration: > 100000 nM
Compound 3 ended at the assay's limit; the forecaster's own chance of this, stated with the estimate: 10%; middle value at least 1.6-fold (0.22 log units) away from the limit.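

In this assay compound 3 gives > 100000 nM, which is a limit of the assay and not a number. Read as floors, the steps are an at least 1.5-fold higher number from compound 2 to compound 3 (0.18 log units; that floor lies within the scatter) and an at least 1.6-fold higher number from compound 1 to compound 3 (0.22 log units; that floor lies within the scatter), so the true size of the change at this aromatic carbon cannot be told from them. What is new is that thiophen-2-yl, with its five-membered aromatic ring, is the first group at this position to leave a compound at the edge of the measurable range, whereas 2-phenylethenyl and 4-cyanophenyl both gave readable numbers: the limit of > 100000 nM in this assay, at which 1 of the 3 values shown sits.

The compounds shown leave open whether an amine, a carboxylic acid or a longer chain on this carbon would give stronger inhibition in this assay. They also leave open what happens when the phenylsulfanyl group, the same in all three compounds, is replaced.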